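The source may hold more compounds than are shown below. What is called first, only, known or untested is meant among the compounds shown, and "the series" means these compounds.

Measured so far:
- compound 1 `CCS(=O)(=O)Nc1ccc(NC(=O)c2cc(C(F)(F)F)cc(C(F)(F)F)c2)cc1C`: 126000 nM
- compound 2 `CCS(=O)(=O)Nc1ccc(NC(=O)c2cc(C(F)(F)F)cc(C(F)(F)F)c2)cc1OC`: a limit, > 250000 nM
- compound 3 `CCS(=O)(=O)Nc1ccc(NC(=O)c2cccc(C(F)(F)F)c2)cc1F`: 94800 nM

In an ADME assay on HEK293 cells (Homo sapiens) for cytotoxicity, read by MTT assay, with a stated time of 48 h (a lower number here means a stronger inhibitor, a higher number a weaker inhibitor), compound 3 gives 94800 nM, the lower of the two plain numbers, although compound 1 with 126000 nM sits within the scatter of it. For compound 2 the result, > 250000 nM, is a limit of the assay and not a number. Compound 4, `CCS(=O)(=O)Nc1ccc(NC(=O)c2cc(C(F)(F)F)cc(C(F)(F)F)c2)cc1F`, differs from compound 3 by trifluoromethyl in place of hydrogen on an aromatic carbon. Among the measured compounds shown here, no measured step adds a trifluoromethyl group; the only step, an at least 1.9-fold higher number from compound 1 to compound 2 (0.29 log units; that floor lies within the scatter), concerns a different exchange and does not bear on this one. The number for compound 4 is therefore expected to stay close to that of compound 3, the estimated step being a 1.2-fold higher number from compound 3 to compound 4 (0.06 log units; within the scatter). Compound 4 is estimated at 110000 nM, between 50000 nM and 250000 nM.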

Compound 4, half-maximal inhibitory concentration: > 250000 nM
Compound 4: a limit, no number; the forecaster's own chance of this, stated with the estimate: 25%; middle value at least 2.2-fold (0.35 log units) from the limit.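

In this assay, among the compounds shown here, adding a trifluoromethyl group on an aromatic carbon, meta to a trifluoromethyl group, gives an at least 2.6-fold higher number from compound 3 to compound 4 (0.42 log units; beyond the scatter), the only step at this place so far and one that clears the scatter. Fluoro in place of methyl gives an at least 1.9-fold higher number from compound 1 to compound 4 (0.29 log units; that floor lies within the scatter), which alone does not separate those two compounds. The step between the two limits cannot be read, and the full size of the other steps to compound 4 stays hidden: the limit of > 250000 nM in this assay, at which 2 of the 4 values shown sit.

On these data alone, what an amine or a carboxylic acid at this place would do stays open. So does whether the trifluoromethyl step holds with methyl or methoxy in place of the fluoro.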